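This account rests on a few compounds, and the source may have more. Where it says the series, first, only, none or still open, it means among the compounds named here.

Compounds 1, 2 and 3 share one core, seen in compound 1 `Cc1c(OCCCCOc2ccccc2C(=O)O)ccc(C(=O)CC(C)C)c1O`, compound 2 `Cc1c(OCCCCOc2ccc(C(=O)O)c(Cl)c2)ccc(C(=O)CC(C)C)c1O` and compound 3 `Cc1c(OCCCCOc2ccc(C(=O)O)cc2Cl)ccc(C(=O)CC(C)C)c1O`; they differ only in the aromatic ring carried on an oxygen on a saturated carbon. In an assay on HEK293 cells for positive allosteric modulation of metabotropic glutamate receptor 3 (Rattus norvegicus), read by thallium flux, with a stated time of 2.5 min (a higher number here means that more compound is needed for the effect, a lower number that less compound is needed), compound 1 gives "not determined" (no result reported), so no number stands for it. Compound 2 gives 2050 nM in this assay, and compound 3 gives 1140 nM. Compound 3 therefore holds the lower of the two numbers, although the step of a 1.8-fold lower number from compound 2 to compound 3 (0.25 log units; within the scatter) is within the scatter and so does not separate the two. Compound 4 `Cc1ccc(C(=O)O)cc1OCCCCOc1ccc(C(=O)CC(C)C)c(O)c1C` has not yet been measured. It differs from compound 3 in this way: 5-carboxy-2-methylphenyl in place of 4-carboxy-2-chlorophenyl on an oxygen on a saturated carbon. Among the compounds with values here, the one measured step, a 1.8-fold lower number from compound 2 to compound 3 (0.25 log units; within the scatter), put 4-carboxy-2-chlorophenyl in place of 4-carboxy-3-chlorophenyl and stayed within the scatter; no measured step puts a methyl where a chlorine stood. On this basis compound 4 is expected to sit near compound 3, with a 1.3-fold higher number from compound 3 to compound 4 (0.12 log units; within the scatter) not beyond the scatter. Compound 4 is estimated at 1500 nM, with a range from 500 nM to 4500 nM.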

Compound 4, half-maximal effective concentration: > 10000 nM
Compound 4 gave a limit, no number; the forecaster's own chance of this, stated with the estimate: 25%; at least 6.6-fold (0.82 log units) between middle value and limit.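

Compound 4 gives no number in this assay, only a limit of the assay: the limit of > 10000 nM in this assay, at which 1 of the 4 values shown sits.

Even as limits, both new steps lie beyond the scatter (an at least 8.7-fold higher number from compound 3 to compound 4 (0.94 log units; beyond the scatter)) (an at least 4.8-fold higher number from compound 2 to compound 4 (0.68 log units; beyond the scatter)), whereas the only earlier step, between the two chlorine-bearing rings of compounds 2 and 3, stayed within it. So this is the first sign that the aromatic ring on this oxygen can matter in this series, with 5-carboxy-2-methylphenyl needing clearly more compound than either 4-carboxy-2-chlorophenyl or 4-carboxy-3-chlorophenyl.

The change to compound 4 swaps chlorine for methyl and also gives a different carboxy placement, so the compounds shown cannot say which of the two accounts for the rise. A 4-carboxy-2-methylphenyl ring, which would separate them, is not among the compounds shown, and compound 1, without chlorine, has no number to compare.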